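The compounds below may be only part of what the source reports. "The series", "measured", "known", "first", "only" and "open" are said of these compounds alone.

Measured compounds in a functional assay on U-251 cells (Homo sapiens) for cytotoxicity, read by sulforhodamine B assay, with a stated time of 48 h, tested at 1 uM; on this read-out lower numbers stand for a stronger effect and higher numbers for a weaker effect at the one concentration tested:
Compound 1 `Cc1cc(O)cc(-c2nn(CC#N)cc2-c2ccnc(-c3ccc(Oc4ccccc4)cc3)c2)c1`: compound 1 gives -97%
Compound 2 `COc1cc(C)cc(-c2nn(CC#N)cc2-c2ccnc(-c3ccc(N(C)C)cc3)c2)c1`: compound 2 gives -5%

Of the two numbers in this assay, compound 2 stands highest; its nearest neighbour is compound 1, whose number lies well below it, beyond the scatter. Compound 3 `Cc1cc(O)cc(-c2nn(CC#N)cc2-c2ccnc(-c3ccc(N(C)C)cc3)c2)c1` is not yet measured. It differs from compound 2 by hydrogen in place of methyl on an oxygen on an aromatic ring, that is, methoxy to hydroxy, the rest being unchanged. Compound 1 also carries a hydroxy, but it differs from compound 2 in a second place as well, so the two values alone settle nothing about this single change. For the step from compound 2 to compound 3 in this assay, a moderate move towards a stronger effect is expected, a number 30 percentage points lower from compound 2 to compound 3 (beyond the scatter). Compound 3 is accordingly estimated at -35%, within a range from -85% to 10%.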

Compound 3, a percentage reported as activity, at one concentration (the size of the read-out at that concentration, not a potency): 8%
For compound 3 the middle estimate is 43 percentage points below the measured one; measured number inside the range.
By their numbers in this assay, from the lowest: compound 1; then compound 2; then compound 3.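

In this assay, methoxy to hydroxy with dimethylamino held constant gives a number 13 percentage points higher from compound 2 to compound 3 (beyond the scatter) and so does not bring the strong effect of compound 1. With the hydroxy held constant, dimethylamino in place of phenoxy gives a number 105 percentage points higher from compound 1 to compound 3 (beyond the scatter) and so places the large difference at that second site. Nothing available explains either step. As far as these compounds go, what remains open is whether a benzyloxy or a plain methoxy in place of phenoxy would keep the strong effect. Also open, from the compounds shown here alone, is whether methoxy to hydroxy would give a similar step with phenoxy present.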